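This account rests on a few compounds, and the source may have more. Where it says the series, first, only, none or still open, it means among the compounds named here.

In an assay on isolated protein for inhibition of Leucine-rich repeat serine/threonine-protein kinase 2 (Homo sapiens), read by TR-FRET and LanthaScreen, with stated times of 50 min and 30 min, in the presence of a further agent that is not named here (on this read-out higher numbers stand for weaker inhibition and lower numbers for stronger inhibition), compound 1 `C[C@@H]1CCCN1c1c(C#N)c2c(N)nc(Nc3cn(C)nc3C(F)(F)F)nc2n1C` gives 508 nM, the lowest of the three numbers measured here. Compound 2 `C[C@H]1CCCN1c1c(C#N)c2c(N)ncnc2n1C` gives 5660 nM, and compound 3 `Cn1c(-c2ccccc2)c(C#N)c2c(N)ncnc21` gives 1260 nM. Going by the values given here, the only measured step between two compounds that differ in one place is a 4.5-fold lower number from compound 2 to compound 3 (0.65 log units; beyond the scatter), and that change sits on an aromatic carbon of the shared core, not where compound 1 and compound 4 part ways. Compound 4 `Cc1nn(C2COC2)cc1Nc1nc(N)c2c(C#N)c(N3CCC[C@H]3C)n(C)c2n1` differs from compound 1 by 3-methyl-1-(oxetan-3-yl)-1H-pyrazol-4-yl in place of 1-methyl-3-(trifluoromethyl)-1H-pyrazol-4-yl on a nitrogen on an aromatic ring. Among the compounds with values here, no measured pair shows what this exchange does: compound 2 lacks the 1-methyl-3-(trifluoromethyl)-1H-pyrazol-4-yl group altogether, so its gap to compound 1 reflects the presence of that whole group rather than the swap of one such group for another. With nothing pointing either way, a change within the scatter is expected, a 1.2-fold higher number from compound 1 to compound 4 (0.07 log units; within the scatter). Compound 4 is therefore estimated to give 600 nM, with a likely range from 200 nM to 1800 nM.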

Compound 4, half-maximal inhibitory concentration: 38 nM
For compound 4 the middle estimate is 16-fold (1.20 log units) above the measured one, outside the stated range (below it).
By their numbers in this assay, from the lowest: compound 4; then compound 1; then compound 3; then compound 2.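

In this assay, going by these compounds alone, the choice of group on this nitrogen on an aromatic ring matters far more than the earlier compounds could show, with a 13-fold lower number from compound 1 to compound 4 (1.13 log units; beyond the scatter). Compound 2 lacks such a group altogether, so its gap to compound 1 could not show that one substituted pyrazole differs so strongly from another. Here both groups have the same count of heavy atoms and one five-membered aromatic ring, yet the outcome differs widely, and no measurement shown explains why.

The exchange removes trifluoromethyl while introducing a methyl and an oxetan-3-yl ring together, so the compounds shown cannot assign the step to any one of these parts. Also open, going by these compounds, is how the pyrazole would fare with a simple methyl in place of the oxetan-3-yl ring, or with a morpholine or a carboxylic acid group attached to it.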